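The source may report more compounds than this note shows. Statements on the series, on what has been measured and on what is new or still open speak of the compounds shown alone.

Measured so far:
Compound 1 `Cc1ccc2c(n1)C(=O)C(Cl)=C(Cl)C2=O`: in a functional assay on cells (Neutrophil, Homo sapiens) for inhibition, read by WST assay, with a stated time of 20 min (a higher number here means a weaker inhibitor, a lower number a stronger inhibitor), compound 1 gives 3400 nM.
Compound 2 `CNC1=C(Cl)C(=O)c2ncccc2C1=O`: in this assay compound 2 gives 78900 nM.
Compound 3 `CNC1=C(SC)C(=O)c2ncccc2C1=O`: in this assay compound 3 gives only a limit, > 200000 nM.

Compound 3 therefore stands at the limit of this assay the limit of > 200000 nM in this assay, at which 1 of the 3 values shown sits, and no number is known for it. Among the measured compounds shown here, the only measured step touching this position is an at least 2.5-fold higher number from compound 2 to compound 3 (0.40 log units; beyond the scatter), which moved the value up to that limit. Compound 4 `CNC1=C(Sc2ccccc2)C(=O)c2ncccc2C1=O` differs from compound 3 by phenyl in place of methyl on a sulfur. For the measured compounds named here, no measured step changes the group carried on the sulfur itself, so nothing in the measured data sets a direction. With compound 3 already at the limit, a number for compound 4 is expected only if the change lowers the value well beyond the scatter; the expected step is a number no higher from compound 3 to compound 4 (the limit leaves the size open), small. Compound 4 is estimated at 200000 nM, within 50000 nM to 600000 nM, most likely again reported as a limit.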

Compound 4, half-maximal inhibitory concentration: > 150000 nM
Compound 4: only a limit was reported; the forecaster's own chance of this, stated with the estimate: 60%; the middle value does not contradict the limit.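

In this assay, compound 4 is again reported only as a limit, > 150000 nM. Phenylsulfanyl in place of chloro gives an at least 1.9-fold higher number from compound 2 to compound 4 (0.27 log units; that floor lies within the scatter), so this floor alone does not separate compound 4 from compound 2, whereas the step to methylsulfanyl in compound 3 is printed as beyond the scatter. The step between the two sulfur compounds cannot be read, which leaves phenyl and methyl on the sulfur unordered.

Open, from the compounds shown here alone, is whether any group on the sulfur gives a number rather than a limit. A carboxylic acid or an amine on a longer chain there remains untested among the compounds shown.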